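Diol to Diamine on the Sulfur Side Chain

This account rests on a few compounds, and the source may have more. Where it says the series, first, only, none or still open, it means among the compounds named here.

Compound 3 `CC(C)c1n[nH]c2c(NCc3ccc(-c4ccccn4)cc3)nc(SCC(O)CO)nc12` stands lowest of the three numbers in a functional assay on HT cells (Homo sapiens) for antiproliferative activity, read by fluorescence, with a stated time of 72 h (a lower number here means a stronger inhibitor of growth, a higher number a weaker inhibitor of growth), where compound 3 gives 21 nM. Compound 1 `CC(C)c1n[nH]c2c(NCc3ccc(-c4ccccn4)cc3)nc(SCCC(N)=O)nc12` gives 120 nM, and compound 2 `CSc1nc(NCc2ccc(-c3ccccn3)cc2)c2[nH]nc(C(C)C)c2n1` gives 783 nM. The steps of a 37-fold lower number from compound 2 to compound 3 (1.57 log units; beyond the scatter) and a 5.7-fold lower number from compound 1 to compound 3 (0.76 log units; beyond the scatter) show that the 1,2-dihydroxyethyl group on the saturated chain carbon bound to a sulfur gave the strongest growth inhibition of the three. Compound 4 `CC(C)c1n[nH]c2c(NCc3ccc(-c4ccccn4)cc3)nc(SCC(N)CN)nc12` differs from compound 3 by 1,2-diaminoethyl in place of 1,2-dihydroxyethyl on a saturated chain carbon bound to a sulfur. Going by the values given here, no measured step exchanges one group for another of equal donor and acceptor count at this place, so the bearing of the earlier steps is indirect. A step within or near the scatter, a 1.9-fold higher number from compound 3 to compound 4 (0.28 log units; within the scatter), is therefore expected for compound 4, whose value is estimated at 40 nM, with a range from 10 nM to 200 nM.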

Compound 4, concentration for 50% growth inhibition: 480 nM
Compound 4: middle estimate off by 12-fold (1.08 log units), on the low side; the whole stated range lies below it.
By their numbers in this assay, from the lowest: compound 3; then compound 1; then compounds 4 and 2 (each within the scatter of the next).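

At this place, on a saturated chain carbon bound to a sulfur, equal counts of donors and acceptors did not keep the activity in this assay: 1,2-diaminoethyl in place of 1,2-dihydroxyethyl gave a 23-fold higher number from compound 3 to compound 4 (1.36 log units; beyond the scatter). The gain seen with 1,2-dihydroxyethyl over hydrogen did not carry over to 1,2-diaminoethyl, which gave a 1.6-fold lower number from compound 2 to compound 4 (0.21 log units; within the scatter). Carbamoylmethyl also compared better, with a 4.0-fold higher number from compound 1 to compound 4 (0.60 log units; beyond the scatter).

Nothing available here explains the loss. The compounds shown leave open whether a single amine with one hydroxyl kept, or a carboxylic acid, would follow the diol or the diamine at this place.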